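Swapping the phenyl of compound 1 for a methylfuran ring

The source may report more compounds than this note shows. Statements on the series, on what has been measured and on what is new or still open speak of the compounds shown alone.

Measured compounds:
- compound 1 `N#CC1=C(N)N(c2ccc(S(N)(=O)=O)cc2)C2=C(C(=O)CCC2)C1c1ccccc1`: 10%
- compound 2 `COc1cc(CC2C(C#N)=C(N)N(c3ccc(S(N)(=O)=O)cc3)C3=C2C(=O)CCC3)ccc1O`: 0%
- compound 3 `N#CC1=C(N)N(c2ccc(S(N)(=O)=O)cc2)C2=C(C(=O)CCC2)C1c1ccc([N+](=O)[O-])cc1`: 85%

In a functional assay on Ehrlich cells (Mus musculus) for antiproliferative activity, read by trypan blue exclusion, with a stated time of 2 h, tested at 10 ug/mL (a lower number here means a weaker effect, a higher number a stronger effect of the compound at the concentration tested), compound 1 gives 10%, the second highest of the three numbers. Compound 2 sits nearest, a number 10 percentage points lower from compound 1 to compound 2 (within the scatter). Compound 3 stands furthest away, a number 75 percentage points higher from compound 1 to compound 3 (beyond the scatter), and also a number 85 percentage points higher from compound 2 to compound 3 (beyond the scatter).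

Compound 4 `Cc1ccoc1C1C(C#N)=C(N)N(c2ccc(S(N)(=O)=O)cc2)C2=C1C(=O)CCC2` is not yet measured. Compared with compound 1 it carries 3-methylfuran-2-yl in place of phenyl on a saturated ring carbon.

Among the compounds with values here, only one measured step changes the group on the same saturated ring carbon without adding a nitro group: the step from compound 1 to compound 2 stayed within the scatter. The large gains seen on the way to compound 3 both rest on the nitro group, which compound 4 does not have. Compound 4 is therefore expected to move little, a number 2 percentage points higher from compound 1 to compound 4 (within the scatter), staying in the scatter around compound 1 in this assay. The estimate for compound 4 is 12%, expected between 0% and 35%.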

Compound 4, a percentage reported as activity, at one concentration (the size of the read-out at that concentration, not a potency): 2%
Compound 4: the middle estimate sits 10 percentage points above what was measured, within the range that was stated.
By their numbers in this assay, from the lowest: compounds 2, 4 and 1 (each within the scatter of the next); then compound 3.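

In this assay, a five-membered oxygen-containing ring, 3-methylfuran-2-yl, stands on this saturated ring carbon in place of phenyl with a number 8 percentage points lower from compound 1 to compound 4 (within the scatter) and in place of 4-hydroxy-3-methoxybenzyl with a number 2 percentage points higher from compound 2 to compound 4 (within the scatter) so three quite different groups here now give readings that cannot be told apart. Against these, the furan in place of 4-nitrophenyl gives a number 83 percentage points lower from compound 3 to compound 4 (beyond the scatter) and compound 3 remains the only one of the four that stands clear of the others. Nothing at hand speaks to what lies behind this split.

Open, going by these compounds, is whether a 4-aminophenyl or 4-carboxyphenyl group on this carbon would read like compound 3 or like compound 1. Also open, on these data alone, is whether a nitro group placed on the furan ring would give a high reading too.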